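The source may hold more compounds than are shown below. What is called first, only, known or untested is meant among the compounds shown, and "the series" means these compounds.

Compound 2 `C/N=C(\S)NCCCCCn1nc(-c2ccccc2)ccc1=O` stands lowest of the two numbers at hand: in a functional assay on the whole organism with Rattus norvegicus as the target, at a dose of 100 mg/kg (a higher number here means more inhibition at the dose given (going by the name of the read-out), a lower number less inhibition), compound 2 gives 68.9%, while compound 1 `CN(C)/C(=N/CCCCn1nc(-c2ccccc2)ccc1=O)NC#N` gives 80.7% in this assay. Among the compounds with values here, the one measured step, a number 11.8 percentage points lower from compound 1 to compound 2 (beyond the scatter), is the only comparison available, and it exchanged a cyano-bearing amidine-type group for a thiourea-type group on the chain.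

Compound 3 `N#CNC(=N)NCCCn1nc(-c2ccccc2)ccc1=O` is not yet measured. Its change from compound 2 is a group of 6 heavy atoms (2 carbon, 4 nitrogen; no ring) in place of a group of 7 heavy atoms (4 carbon, 2 nitrogen, 1 sulfur; no ring), on a saturated chain carbon, three bonds along the chain from an aromatic nitrogen — a move back toward a nitrogen-rich group of the kind carried by compound 1, though on a shorter chain. Within the data shown here, because a number 11.8 percentage points lower from compound 1 to compound 2 (beyond the scatter) was modest and ran downward, the reverse kind of exchange is expected to give a modest upward step in this assay; the shorter chain has no measured precedent here. The expected step from compound 2 to compound 3 is a number 7.1 percentage points higher from compound 2 to compound 3 (within the scatter). Compound 3 is therefore estimated at 76% in this assay, with a range from 60% to 90%.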

Compound 3, a percentage reported as inhibition, in the whole organism at one dose (the size of the read-out at that dose, not a potency): 33.3%
For compound 3 the middle estimate is 42.7 percentage points above the measured one; measured number outside the range, below it.
By their numbers in this assay, from the lowest: compound 3; then compound 2; then compound 1.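

In this assay, this position proves far more sensitive than the earlier pair suggested: the exchange on the saturated chain carbon, three bonds along the chain from an aromatic nitrogen, gives a number 35.6 percentage points lower from compound 2 to compound 3 (beyond the scatter), a large step where a number 11.8 percentage points lower from compound 1 to compound 2 (beyond the scatter) was modest. A group of 6 heavy atoms with 4 nitrogen and no sulfur therefore does not keep the inhibition seen with the sulfur-bearing group of compound 2, so a nitrogen-rich chain end does not carry a high number by itself. No measurement on hand explains the drop.

As far as these compounds go, the change shortens the chain and replaces the end group at once, so the share of each in the step remains open. From the compounds shown here alone, whether the same end group on a longer chain, or a simple amine at the chain end, would restore the inhibition also remains unknown.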